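Swapping the Piperazine Aryl Group: Carbamoyl to Fluorine

A few compounds are considered here, and "the series" means these few. Any claim that something is new, unique, unknown or untested is made for them only; others in the source may bear on it.

Three compounds share a core in which an oxazole carbonyl links to a piperazine carrying an aryl group. Compound 1 `Cc1nc(-c2ccccc2F)c(C(=O)N2CCN(c3cc(Cl)ccc3C)CC2)o1` gives 229 nM in a functional assay on HL-60 cells (Homo sapiens) for inhibition, read by MTT assay, with a stated time of 72 h; on this read-out lower numbers stand for stronger inhibition and higher numbers for weaker inhibition. Compound 2 `O=C(c1oc(C(F)(F)F)nc1-c1ccccc1F)N1CCN(c2cccc(Cl)c2)CC1` is reported in this assay as "not active" (no number reported). Compound 3 `Cc1nc(-c2ccccc2)c(C(=O)N2CCN(c3cccc(C(N)=O)c3)CC2)o1` gives 71 nM in this assay, the lowest of the two numbers recorded; its gap to compound 1 lies beyond the usual scatter, although the two also differ in several places at once.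

Compound 4 `Cc1nc(-c2ccccc2)c(C(=O)N2CCN(c3ccc(F)cc3)CC2)o1` has not yet been measured. It differs from compound 3 in one place: 4-fluorophenyl in place of 3-carbamoylphenyl on an amine nitrogen in a ring. Among the compounds with values here, no single-change step between measured compounds is available for comparison, so the expectation rests on the hydrogen-bond donor and acceptor that leave with the carbamoyl group and on compound 1, whose value 229 nM shows that other aryl groups on this ring nitrogen give higher numbers. The step from compound 3 to compound 4 is expected to be a 4.2-fold higher number from compound 3 to compound 4 (0.63 log units; beyond the scatter), towards weaker inhibition. Compound 4 is estimated at 300 nM, within 80 nM to 1500 nM.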

Compound 4, half-maximal inhibitory concentration: > 1000 nM
Compound 4 gave a limit, no number (the forecaster's own chance of this, stated with the estimate: 20%); middle value at least 3.3-fold (0.52 log units) from the limit.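

Putting 4-fluorophenyl in place of 3-carbamoylphenyl on an amine nitrogen in a ring gives an at least 14-fold higher number from compound 3 to compound 4 (1.14 log units; beyond the scatter) in this assay. Within the data shown here, this is the first single-change comparison in the set, and it shows that the aryl group at this position strongly shapes the result. The value of compound 4 is a limit of the assay, not a number: the limit of > 1000 nM in this assay, at which 1 of the 4 values shown sits.

The step swaps the group and also its place on the aryl ring, and the hydrogen-bond donor and acceptor of 3-carbamoylphenyl leave with it, so the compounds shown cannot separate these changes. A 3-fluorophenyl group, a 4-carbamoylphenyl group, or a 3-carboxyphenyl group, which has a carboxylic acid in place of the carbamoyl group, on the same core would tell them apart.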